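The compounds below may be only part of what the source reports. "The series", "measured", "known", "first", "only" and "open" are said of these compounds alone.

Measured to date:
compound 1, `Cc1ccc(C(=O)NNC(=S)Nc2csc(-c3ccc(C)cc3)c2)cc1`, 38000 nM in a functional assay on U-373MG ATCC cells (Homo sapiens) for inhibition, read by colorimetric assay and MTT assay, with a stated time of 72 h; on this read-out lower numbers stand for stronger inhibition and higher numbers for weaker inhibition.
compound 2, `COc1ccc(C(=O)NNC(=S)Nc2csc(-c3ccc(C)cc3)c2)cc1`, 19000 nM in this assay.
compound 3, `O=C(NNC(=S)Nc1csc(-c2ccccc2)c1)c1ccc(O)cc1`, which reaches only the limit of this assay at > 100000 nM.

Compound 3 therefore stands at a limit and gives no number; it is the one that sits at the limit of > 100000 nM in this assay, at which 1 of the 3 values shown sits. Compound 4 is `Cc1ccc(-c2cc(NC(=S)NNC(=O)c3ccc(O)cc3)cs2)cc1`. The difference from compound 3 to compound 4 is methyl in place of hydrogen on an aromatic carbon, a methyl in place of hydrogen on an aromatic carbon of the phenyl on the shared core. Among the compounds with values here, the only measured step in this assay, a 2.0-fold lower number from compound 1 to compound 2 (0.30 log units; within the scatter), concerns a substituent on the other ring and stays within the scatter, so no measured step speaks directly to this change. Compound 4 is therefore expected near the limit; its estimate is 80000 nM, with a range from 25000 nM to 200000 nM, a step of an at least 1.2-fold lower number from compound 3 to compound 4 (0.09 log units; that floor lies within the scatter) that is expected only loosely.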

Compound 4, half-maximal inhibitory concentration: 64000 nM
The estimate for compound 4 lay 1.3-fold (0.10 log units) above the measured number; the measured number falls inside the stated range.
By their numbers in this assay, from the lowest: compounds 2, 1 and 4 (each within the scatter of the next, the first and the last beyond it). At a limit, above all of these: compound 3.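

Compound 3 is held at a limit and gives no number: the limit of > 100000 nM in this assay, at which 1 of the 4 values shown sits.
Against that limit, an at least 1.5-fold lower number from compound 3 to compound 4 (0.19 log units; that floor lies within the scatter) is only a floor within the scatter, so the methyl in place of hydrogen is not shown to matter in this assay at this position.
With the 4-methylphenyl group held, a 3.4-fold higher number from compound 2 to compound 4 (0.53 log units; beyond the scatter) lies beyond the scatter, while a 1.7-fold higher number from compound 1 to compound 4 (0.23 log units; within the scatter) stays within it.

From the compounds shown here alone, what an amine or a longer chain in place of this methyl would give stays open. So does whether phenyl to 4-methylphenyl reads the same with methoxy on the other ring.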